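Three anilides at the assay limit, a fourth awaited

The source may hold more compounds than are shown below. What is called first, only, known or untested is meant among the compounds shown, and "the series" means these compounds.

The shared core carries an amide whose carbonyl side varies. Compound 1 `O=C(Nc1ccc(Cl)c(-c2nnc3c(Cl)cccn23)c1)c1cccnc1` bears a pyridin-3-yl group on the carbonyl carbon. In a functional assay on MDA-MB-231 cells (Homo sapiens) for antiproliferative activity, read by MTT assay, with stated times of 72 h and 4 h (on this read-out higher numbers stand for weaker inhibition and lower numbers for stronger inhibition), compound 1 reaches only the limit of the assay, > 100000 nM. Compound 2 `O=C(Nc1ccc(Cl)c(-c2nnc3c(Cl)cccn23)c1)c1ccc(C(F)(F)F)cc1F` carries a different aryl group on that carbon. In this assay compound 2 likewise stops at a limit, > 100000 nM. Compound 3 `Cc1cc(Cl)ccc1C(=O)Nc1ccc(Cl)c(-c2nnc3c(Cl)cccn23)c1` carries 4-chloro-2-methylphenyl on the carbonyl carbon. In this assay compound 3 also gives only a limit, > 100000 nM. Compound 3 therefore stands nowhere readable on the scale: the step that the two limits leave unreadable from compound 1 to compound 3 has two limits for its ends and cannot be sized. the limit of > 100000 nM in this assay, at which 3 of the 3 values shown sit, is all that the numbers show. Compound 4 `O=C(Nc1ccc(Cl)c(-c2nnc3c(Cl)cccn23)c1)c1ccccc1Cl` differs from compound 3 by 2-chlorophenyl in place of 4-chloro-2-methylphenyl on a carbonyl carbon. Among the measured compounds shown here, no measured step gives a direction or size for this change. Compound 4 is expected to sit near the limit as well, the expected step being a step that the limit leaves unreadable from compound 3 to compound 4. The estimate for compound 4 is 150000 nM, with a range from 30000 nM to 600000 nM, and the assay will most probably report only a limit again.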

Compound 4, half-maximal inhibitory concentration: 59900 nM
The estimate for compound 4 lay 2.5-fold (0.40 log units) above the measured number, within the range that was stated.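

Among the compounds shown here, compound 4 is the first compound here to give a number rather than a limit in this assay, so a group on this carbonyl carbon can bring the value onto the readable scale. Placing 2-chlorophenyl there gives an at least 1.6-fold lower number from compound 3 to compound 4 (0.22 log units; that floor lies within the scatter), and it gives an at least 1.6-fold lower number from compound 1 to compound 4 (0.22 log units; that floor lies within the scatter), so neither change can yet be called a real gain. The remaining steps cannot be read because they rest on limits alone: the limit of > 100000 nM in this assay, at which 3 of the 4 values shown sit.

The compounds shown carry only aromatic rings on the carbonyl carbon, which leaves open how a benzyl group, an amine or a longer chain would behave there. They also leave open which part of the change from 4-chloro-2-methylphenyl to 2-chlorophenyl matters, the methyl group or the chlorine.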